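The source may hold more compounds than are shown below. What is called first, only, known or untested is meant among the compounds shown, and "the series" means these compounds.

Compound 1, `CCC(=O)N1c2ccccc2CCC1C(=O)Nc1ccccc1C(F)(F)F`, reaches only the limit of a functional assay on NUGC-3 cells (Homo sapiens) for cytotoxicity, read by sulforhodamine B assay, with a stated time of 72 h (on this read-out higher numbers stand for weaker inhibition of growth and lower numbers for stronger inhibition of growth), where compound 1 gives > 80000 nM. That value is a limit of the assay, not a number, and it leaves compound 1 without a fixed place among the values shown. Compound 2, `CCC(=O)N1c2ccccc2CCC1C(=O)Nc1cc(C(F)(F)F)cc(C(F)(F)F)c1`, gives 7220 nM in this assay, and compound 3, `O=C(Nc1cc(C(F)(F)F)cc(C(F)(F)F)c1)C1CCc2ccccc2N1`, gives 8760 nM. Going by the values given here, the one step measured between these two, a 1.2-fold higher number from compound 2 to compound 3 (0.08 log units; within the scatter), shows that exchanging the group on the ring nitrogen made no difference beyond the scatter.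

Compound 4, `CC(=O)N1c2ccccc2CCC1C(=O)Nc1ccccc1C(F)(F)F`, differs from compound 1 by hydrogen in place of methyl on a saturated chain carbon bound to a carbonyl carbon. Among the compounds with values here, the only measured step that touches the same nitrogen is a 1.2-fold higher number from compound 2 to compound 3 (0.08 log units; within the scatter); it was within the scatter, and it removed the whole propanoyl rather than shortening it. Since compound 1 sits at the limit of > 80000 nM in this assay, at which 1 of the 3 values shown sits, no measured change of this kind gives reason to expect a number inside the measurable range for compound 4. The expected step is a step that the limit leaves unreadable from compound 1 to compound 4, which amounts to no change beyond the scatter. Compound 4 is therefore estimated at 100000 nM, with a range from 20000 nM to 400000 nM, and it will most likely be reported again as a limit.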

Compound 4, concentration for 50% growth inhibition: > 80000 nM
Compound 4: a limit, no number; the forecaster's own chance of this, stated with the estimate: 70%; the middle value is on the limit's open side.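

Compound 1 and compound 4 both end at a limit of this assay rather than at a number, so the change from propanoyl to acetyl yields no readable step: the limit of > 80000 nM in this assay, at which 2 of the 4 values shown sit. The compounds shown leave open whether this change alters growth inhibition at all, and where either compound would fall on a measured scale.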